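The source may hold more compounds than are shown below. What is called first, only, known or untested is meant among the compounds shown, and "the series" means these compounds.

Working notes on the acylguanidine series. All three measured compounds share one core, a guanidine carrying the three-carbon chain to the imidazole, and differ only in the acyl group on that guanidine. Compound 1, `CC(C(=O)NC(=N)NCCCc1c[nH]cn1)c1ccccc1`, is tested in a functional assay on ileum for antagonist activity at histamine H1 receptor (Cavia porcellus) (on this read-out higher numbers stand for weaker binding and lower numbers for tighter binding), and gives only a limit there, > 10000 nM, which is the limit of > 10000 nM in this assay, at which 1 of the 3 values shown sits. Compound 2, `CC(CC(=O)/N=C(\N)NCCCc1c[nH]cn1)c1ccccc1`, gives in this assay 1350 nM. Compound 3, `N=C(NCCCc1c[nH]cn1)NC(=O)c1ccccc1`, has the phenyl on the carbonyl carbon; in this assay compound 3 gives only a limit, < 10000 nM, which is the limit of < 10000 nM in this assay, at which 1 of the 3 values shown sits. Compound 3 therefore stands among the three values without a number of its own; the one number shown in this assay is that of compound 2, 1350 nM. The values of compound 1 and compound 3 are limits and not numbers.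

Compound 4, `N=C(NCCCc1c[nH]cn1)NC(=O)C1CCCCC1`, differs from compound 3 in one place: cyclohexyl in place of phenyl on a carbonyl carbon. Within the data shown here, no pair of measured compounds isolates this change; compound 1 and compound 2 differ from compound 3 in more than one place at once. The step from compound 3 to compound 4 is expected to stay within the usual scatter, a step that the limit leaves unreadable from compound 3 to compound 4. For compound 4 the estimate in this assay is 5000 nM, between 1000 nM and 20000 nM.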

Compound 4, dissociation constant: 5130 nM
The estimate for compound 4 lay 1.0-fold (0.01 log units) below the measured number; low and high end bracket the measured number.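

No step from compound 3 to compound 4 can be read in this assay, since compound 3 has only a limit there and not a number: the limit of < 10000 nM in this assay, at which 1 of the 4 values shown sits.

The compounds shown leave open whether cyclohexyl in place of phenyl on a carbonyl carbon changes the value in this assay at all, and in which direction.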